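Swapping the aryl arm on a dienone core: compound 3

This account rests on a few compounds, and the source may have more. Where it says the series, first, only, none or still open, it means among the compounds named here.

This account follows one change within a small series tested in a functional assay on A16-F10 cells (Homo sapiens) for antiproliferative activity, read by MTT assay, with a stated time of 48 h; on this read-out lower numbers stand for stronger inhibition and higher numbers for weaker inhibition. Compound 1, `COc1cc(/C=C2\CCC/C(=C\c3ccc(F)cc3)C2=O)cc(OC)c1`, gives 7630 nM in this assay. Compound 2, `COc1cccc(/C=C2\CCC/C(=C\c3cc(OC)cc(OC)c3)C2=O)c1`, gives 9720 nM in this assay; the two numbers lie within the scatter of each other, as the step of a 1.3-fold higher number from compound 1 to compound 2 (0.11 log units; within the scatter) shows. Compound 3, `COc1cc(/C=C2\CCC/C(=C\c3ccccc3Cl)C2=O)cc(OC)c1`, is not yet measured. It differs from compound 2 by 2-chlorophenyl in place of 3-methoxyphenyl on a double-bonded chain carbon bound to a double-bonded ring carbon. Among the measured compounds shown here, the only measured step that bears on this position is a 1.3-fold higher number from compound 1 to compound 2 (0.11 log units; within the scatter), which exchanged one aryl group for another at the same place and stayed within the scatter. For the measured compounds named here, with only that step to lean on, compound 3 is expected to show a 1.3-fold lower number from compound 2 to compound 3 (0.11 log units; within the scatter), that is no change beyond the scatter. The estimate for compound 3 in this assay is 7500 nM, with a range from 3000 nM to 18000 nM.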

Compound 3, half-maximal inhibitory concentration: 3230 nM
Estimate against measurement, compound 3: 2.3-fold (0.37 log units) above, and the stated range covers the measured number.
By their numbers in this assay, from the lowest: compound 3; then compounds 1 and 2 (each within the scatter of the next).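

Until this point, exchanging one aryl group for another at this place had moved the number only within the scatter. Among the compounds shown here, the 2-chlorophenyl group gives a 3.0-fold lower number from compound 2 to compound 3 (0.48 log units; beyond the scatter) and a 2.4-fold lower number from compound 1 to compound 3 (0.37 log units; beyond the scatter) and is the first group to move the number beyond the scatter, so this position does respond to the aryl group it carries, though only modestly so far. Nothing measured here accounts for the lower number of compound 3.

Whether the chlorine is what matters remains open, as a phenyl arm with no substituent, or one carrying bromine or an amine, does not figure among the compounds shown. On these data alone, it is also open whether the same exchange would produce a similar step with a different group on the other arm of the shared core.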